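Dimethylamino for Methoxyethylthio on the Five-Membered Ring

The source may hold more compounds than are shown below. What is called first, only, known or untested is meant among the compounds shown, and "the series" means these compounds.

Three compounds carry numbers in an assay for inhibition of MAP kinase-interacting serine/threonine-protein kinase 2 (Homo sapiens), read by TR-FRET; on this read-out higher numbers stand for weaker inhibition and lower numbers for stronger inhibition. Compound 1 `CCn1cc(-c2ccnc(Nc3ccc(OC)cc3OC)n2)c2ccccc21` gives 430 nM. Compound 2 `Oc1ccccc1Nc1nccc(-c2c[nH]c3ccccc23)n1` gives 120 nM. Compound 3 `COCCSc1nc(C)c(-c2ccnc(Nc3ccc(OC)cc3OC)n2)s1` gives 1700 nM, the highest number of the three; its gap to compound 1 and its larger gap to compound 2 both lie beyond the usual scatter, so compound 3 is the weakest inhibitor of the set as it stands.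

Compound 4 `COc1ccc(Nc2nccc(-c3sc(N(C)C)nc3C)n2)c(OC)c1` is not yet measured. It differs from compound 3 in one place: dimethylamino in place of (2-methoxyethyl)sulfanyl on an aromatic carbon. The exchange sits on an aromatic carbon of the five-membered aromatic ring with one nitrogen and one sulfur, two ring bonds from the ring atom that bears the large group and two ring bonds from the ring atom that bears the methyl group; everything else in compound 3 is kept.

For the measured compounds named here, no measured pair shows this exchange, so no step can be read directly. The expectation rests only on the spread of the three numbers and on the fact that the change stays within the weakest member of the set. A step of a 1.7-fold lower number from compound 3 to compound 4 (0.23 log units; within the scatter) toward a lower number in this assay is expected, of a size at the edge of the scatter. Compound 4 is therefore estimated at 1000 nM in this assay, with a range from 350 nM to 3000 nM.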

Compound 4, inhibition constant: 200 nM
Estimate against measurement, compound 4: 5.0-fold (0.70 log units) above; the whole stated range lies above it.
By their numbers in this assay, from the lowest: compounds 2 and 4 (each within the scatter of the next); then compound 1; then compound 3.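

In this assay, for the compounds shown here, dimethylamino in place of (2-methoxyethyl)sulfanyl on the aromatic carbon next to the ring nitrogen and next to the ring sulfur gives an 8.5-fold lower number from compound 3 to compound 4 (0.93 log units; beyond the scatter), the first step that can be read directly. This position is therefore not indifferent to what it carries: with everything else in compound 3 kept, an exchange from 5 heavy atoms to 3, and from 2 hydrogen-bond acceptors to 1, moves the number beyond the scatter. Nothing at hand accounts for the size of this step.

A single pair cannot separate the effect of a nitrogen bound directly to this ring carbon from that of losing the chain, so a methoxy, a methylamino or a pyrrolidine at the same carbon remains the open comparison. Also open, going by these compounds, is how far the number moves with a longer chain on the nitrogen, such as diethylamino, or with a carboxylic acid or a primary amine on this carbon.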